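The source may hold more compounds than are shown below. What is called first, only, known or untested is meant among the compounds shown, and "the series" means these compounds.

Compound 1 `COC1=C(C)C(=O)/C(=C(O)/C=C/c2cccc(OC)c2)C(=O)C1(C)C` stands lowest of the two numbers obtained so far: in a functional assay on A549 cells (Homo sapiens) for cytotoxicity (on this read-out lower numbers stand for an effect already at smaller amounts and higher numbers for an effect only at larger amounts of compound), compound 1 gives 2.8 ug/mL. Compound 2 `CCc1ccc(/C=C/C(O)=C2/C(=O)C(C)=C(OC)C(C)(C)C2=O)cc1` gives 6.1 ug/mL in this assay. Among the measured compounds shown here, the only measured step, a 2.2-fold higher number from compound 1 to compound 2 (0.34 log units; beyond the scatter), exchanged one aromatic ring for another at the same place. Compound 3 `COC1=C(C)C(=O)/C(=C(O)/C=C/c2ccco2)C(=O)C1(C)C` differs from compound 1 by furan-2-yl in place of 3-methoxyphenyl on a double-bonded chain carbon bound to a double-bonded chain carbon. That measured step swapped a different ring and bears only loosely on this change. For compound 3 a small step is expected, with an estimate of 4.5 ug/mL and a range from 1.8 ug/mL to 11 ug/mL, which would mean a 1.6-fold higher number from compound 1 to compound 3 (0.21 log units; within the scatter).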

Compound 3, concentration for half-maximal effect: 10 ug/mL
Compound 3: middle estimate off by 2.2-fold (0.35 log units), on the low side, within the range that was stated.
By their numbers in this assay, from the lowest: compound 1; then compounds 2 and 3 (each within the scatter of the next).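

Replacing the 3-methoxyphenyl on the double-bonded chain carbon with furan-2-yl does matter in this assay (a 3.6-fold higher number from compound 1 to compound 3 (0.55 log units; beyond the scatter)). Exchanging 4-ethylphenyl for the same furan-2-yl stays small by comparison (a 1.6-fold higher number from compound 2 to compound 3 (0.21 log units; within the scatter)), so at this place compound 1 stands clearly apart from both other compounds, while compound 2 and compound 3 cannot be told apart. No independent data explain this difference. Still open, going by these compounds, is how this place would respond to a group without a ring, such as a longer alkyl chain, or to a phenyl ring carrying an amine or a carboxylic acid.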